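Exchanging the Fluorophenyl Group for Pyridinyl in Compound 4

The source may hold more compounds than are shown below. What is called first, only, known or untested is meant among the compounds shown, and "the series" means these compounds.

Of the compounds shown here, three sharing one core have been tested in a functional assay on cardiac atrium for agonist activity at histamine H2 receptor (Cavia porcellus); on this read-out lower numbers stand for smaller maximal responses and higher numbers for larger maximal responses. Compound 1 `N=C(NCCCc1c[nH]cn1)NCCC(c1ccc(F)cc1)c1ccccn1` gives 1, compound 2 `N=C(NCCCc1c[nH]cn1)NCCC(c1ccc(C(F)(F)F)cc1)c1ccccn1` gives 0.9, and compound 3 `N=C(NCCCc1c[nH]cn1)NCCC(c1ccccn1)c1ccccc1F` gives 1. Compound 3 therefore sits level with compound 1 at the digits shown, the two together being the highest of the three numbers, and the widest gap among them is a number 0.10 higher from compound 2 to compound 3 (within the scatter).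

Compound 4 `N=C(NCCCc1c[nH]cn1)NCCC(c1ccccn1)c1ccccn1` has not yet been measured. It differs from compound 3 in one place: pyridin-2-yl in place of 2-fluorophenyl on a saturated chain carbon bound to an aromatic carbon and a saturated chain carbon. All three measured steps are exchanges of the group at this same saturated chain carbon, and all stayed within the scatter: a number 0.10 lower from compound 1 to compound 2 (within the scatter), no change at the digits printed from compound 1 to compound 3 (within the scatter) and a number 0.10 higher from compound 2 to compound 3 (within the scatter). For the measured compounds named here, no measured compound carries pyridin-2-yl at this position, so the expectation rests on those three exchanges alone, and a step no larger than the scatter, in no fixed direction, is expected for compound 4. Compound 4 is accordingly estimated to give 0.95 in this assay, within 0.8 to 1. The expected step is a number 0.050 lower from compound 3 to compound 4 (within the scatter).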

Compound 4, intrinsic activity: the largest response reached, as a fraction of the reference agonist's: 1
For compound 4 the middle estimate is 0.050 below the measured one; the range from low to high includes it.
By their numbers in this assay, from the lowest: compounds 2, 1, 3 and 4 (each within the scatter of the next).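

In this assay, the saturated chain carbon bound to an aromatic carbon and a saturated chain carbon now proves to accept a ring with a hetero atom as well: pyridin-2-yl brings a hydrogen-bond acceptor that 2-fluorophenyl lacks, yet the exchange gives no change at the digits printed from compound 3 to compound 4 (within the scatter) at this read-out. The comparisons with the other two groups read no change at the digits printed from compound 1 to compound 4 (within the scatter) and a number 0.10 higher from compound 2 to compound 4 (within the scatter) and leave all four compounds within the scatter of one another, so the tolerance seen among substituted phenyl groups extends to this ring. Nothing available here explains why the maximal response holds across this exchange.

All four compounds carry six-membered aromatic rings on this carbon, and each keeps one pyridin-2-yl there. Going by these compounds, whether a cyclohexyl ring, a simple methyl group or an amine at this carbon would keep the same maximal response remains open.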